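The source may report more compounds than this note shows. Statements on the series, on what has been measured and on what is new or still open speak of the compounds shown alone.

Compound 1 `O=C(/C=C/c1ccc2c(c1)B(O)OC2)c1ccc(Cl)cc1` serves as the starting point. In a functional assay on SK-OV-3 cells (Homo sapiens) for cytotoxicity, read by MTT assay, with a stated time of 48 h (a lower number here means a stronger inhibitor, a higher number a weaker inhibitor), compound 1 gives 3700 nM. Compound 2 `Cc1ccc(C(=O)/C=C/c2ccc3c(c2)B(O)OC3)cc1` differs from it only by a methyl in place of chloro on an aromatic carbon, and in this assay compound 2 gives 3700 nM. The step of no change at the digits printed from compound 1 to compound 2 (within the scatter) shows that this swap made no difference beyond the scatter, so compound 2 stands level with compound 1 on the numbers available.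

Compound 3 `CSc1ccc(C(=O)/C=C/c2ccc3c(c2)B(O)OC3)cc1` has not yet been measured. It differs from compound 2 by methylsulfanyl in place of methyl on an aromatic carbon, placed on an aromatic carbon of a six-membered aromatic ring of carbon only, para to a large group. For the measured compounds named here, the only measured step that bears on this change is the one from compound 1 to compound 2, which altered the same position and produced no change beyond the scatter. On that basis the step of a 1.1-fold lower number from compound 2 to compound 3 (0.02 log units; within the scatter) is expected to be small, with no clear direction. Compound 3 is therefore estimated to give 3500 nM in this assay, within a range of 1500 nM to 8000 nM.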

Compound 3, half-maximal inhibitory concentration: 4100 nM
Compound 3: middle estimate off by 1.2-fold (0.07 log units), on the low side, within the range that was stated.
By their numbers in this assay, from the lowest: compounds 1, 2 and 3 (each within the scatter of the next).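

In this assay the swap of methylsulfanyl for methyl gives a 1.1-fold higher number from compound 2 to compound 3 (0.04 log units; within the scatter) and the swap of methylsulfanyl for chloro gives a 1.1-fold higher number from compound 1 to compound 3 (0.04 log units; within the scatter) at the same place. For the compounds shown here, the earlier pair showed only that two single-atom groups could be exchanged here; this position, on an aromatic carbon of the six-membered ring and para to a large group, has now also taken a group with two heavy atoms, including sulfur and a hydrogen-bond acceptor, without a shift beyond the scatter. No measurement at hand explains why these three groups read alike.

Still open, from the compounds shown here alone, is whether an amine, a carboxylic acid or a longer chain such as butyl at this position would move the number beyond the scatter. The compounds shown also leave open whether any group would do so at another carbon of this ring.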